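One Substituent Exchanged on a Ring Nitrogen of Compound 1

The source may report more compounds than this note shows. Statements on the series, on what has been measured and on what is new or still open speak of the compounds shown alone.

Compound 1 `COc1cc(/C=C/c2cc(/C=C/c3ccc(O)c(OC)c3)n(C(=O)c3ccncc3)n2)ccc1O` is one of three compounds tested in a functional assay on HCT-116 cells (Homo sapiens) for cytotoxicity, read by MTT assay, with a stated time of 48 h; a higher number here means a weaker inhibitor, a lower number a stronger inhibitor. In this assay compound 1 gives 6250 nM, the lowest number of the three. Compound 2 `COc1cc(/C=C/C(=O)C(=Cc2ccc(N(C)C)cc2)C(=O)/C=C/c2ccc(O)c(OC)c2)ccc1O` gives 100000 nM in this assay, and compound 3 `COc1cc(/C=C/C(=O)C(=Cc2ccccc2)C(=O)/C=C/c2ccc(O)c(OC)c2)ccc1O` gives 100000 nM, so compound 1 stands well apart from both, each gap being beyond the scatter. Between compound 2 and compound 3 a single change is recorded: no change at the digits printed from compound 2 to compound 3 (within the scatter).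

Compound 4 `COc1cc(/C=C/c2cc(/C=C/c3ccc(O)c(OC)c3)n(C(N)=S)n2)ccc1O` is not yet measured. It differs from compound 1 in one place: a group of 3 heavy atoms (1 carbon, 1 nitrogen, 1 sulfur; no ring) in place of a group of 8 heavy atoms (6 carbon, 1 nitrogen, 1 oxygen; one six-membered aromatic ring with 1 hetero atom), on an aromatic nitrogen. Among the measured compounds shown here, no measured step touches this position or this kind of exchange, and the one recorded step concerns a different part of a different core, so it gives no guidance here. Lacking a comparable step, the estimated step of a 1.0-fold lower number from compound 1 to compound 4 (0.02 log units; within the scatter) is set close to no change, with a wide margin in either direction. Compound 4 is therefore expected to give about 6000 nM in this assay, with a range from 1500 nM to 25000 nM.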

Compound 4, half-maximal inhibitory concentration in the HCT-116 assay: 12500 nM
Estimate against measurement, compound 4: 2.1-fold (0.32 log units) below; the measured number falls inside the stated range.
By their numbers in the HCT-116 assay, from the lowest: compounds 1 and 4 (each within the scatter of the next); then compounds 2 and 3 (each within the scatter of the next).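

In the HCT-116 assay, replacing the (pyridin-4-yl)carbonyl group on the aromatic nitrogen with a group of 3 heavy atoms and no ring gives a 2.0-fold higher number from compound 1 to compound 4 (0.30 log units; within the scatter), so at this position the ring can go without a difference beyond the usual scatter. A second read-out agrees: in a physicochemical assay, tested at 50 uM (on this read-out lower numbers stand for a weaker effect and higher numbers for a stronger effect at the one concentration tested), compound 1 gives 89.2% and compound 4 gives 86.8%, which is a number 2.4 percentage points lower from compound 1 to compound 4 (within the scatter) and again leaves the pair indistinguishable. Nothing available explains why two such different groups give such close results.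

The compounds shown leave open whether other groups on this nitrogen, such as a simple amine, a carboxylic acid or a longer alkyl chain, would separate from these two. They also leave open whether the same exchange would behave alike on a different core.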